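A few compounds are considered here, and "the series" means these few. Any claim that something is new, unique, unknown or untested is made for them only; others in the source may bear on it.

Working notes on the series, following the change from compound 3 to compound 4.

In a functional assay on HepG2 cells (Homo sapiens) for antiproliferative activity, read by XTT assay, with a stated time of 72 h (a higher number here means a weaker inhibitor, a lower number a stronger inhibitor), compound 1 `Nc1nc2c(c(-c3ccco3)cn2[C@@H]2O[C@H](CO)[C@@H](O)[C@H]2O)c(=O)[nH]1` gives > 20000 nM, which is a limit and not a number. Compound 2 `Nc1nc2c(c(-c3ccoc3)cn2[C@@H]2O[C@H](CO)[C@@H](O)[C@H]2O)c(=O)[nH]1` gives > 20000 nM, again a limit. Compound 3 `Nc1nc2c(c(-c3cccs3)cn2[C@@H]2O[C@H](CO)[C@@H](O)[C@H]2O)c(=O)[nH]1` gives > 20000 nM, also a limit, so compound 3 has no numerical position in the series. All three compounds stand at the limit of > 20000 nM in this assay, at which 3 of the 3 values shown sit.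

The next compound is compound 4 `Nc1nc2c(c(-c3ccsc3)cn2[C@@H]2O[C@H](CO)[C@@H](O)[C@H]2O)c(=O)[nH]1`, with thiophen-3-yl in place of thiophen-2-yl on an aromatic carbon.

Going by the values given here, the closest precedent is the exchange of furan-2-yl for furan-3-yl, which gives a step that the two limits leave unreadable from compound 1 to compound 2. The two exchanges that introduce thiophen-2-yl give a step that the two limits leave unreadable from compound 1 to compound 3 and a step that the two limits leave unreadable from compound 2 to compound 3. None of these steps has a readable size, so they offer no direction for the new change. They show only that none of the three compounds has left the limit in this assay.

No step beyond the usual scatter is therefore expected in either direction, and a further limit is the likeliest report. The estimate corresponds to a number no higher from compound 3 to compound 4 (the limit leaves the size open), an expected step and not a measured one.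

For compound 4 the estimated value is 20000 nM, with an expected range from 8000 nM to 50000 nM.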

Compound 4, half-maximal inhibitory concentration: > 20000 nM
Compound 4: a limit, no number; the forecaster's own chance of this, stated with the estimate: 85%; the middle value lies on the limit itself.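

Compound 4 is again a limit and not a number in this assay and, like compound 1, compound 2 and compound 3, leaves every step linking these compounds unreadable: (the limit of > 20000 nM in this assay, at which 4 of the 4 values shown sit).

The compounds shown leave open the actual potency of all four and whether exchanging furan-2-yl, furan-3-yl, thiophen-2-yl and thiophen-3-yl makes any difference.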